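Compound 4: methylsulfanyl in place of methyl

This account rests on a few compounds, and the source may have more. Where it says the series, first, only, none or still open, it means among the compounds named here.

Compound 2 (`COc1cc(C(=O)c2sc3ccccc3c2-c2ccc(C)cc2)cc(OC)c1OC`) gives 1400 nM in a functional assay on HL-60 cells (Homo sapiens) for antiproliferative activity, read by MTT assay, with a stated time of 72 h (a lower number here means a stronger inhibitor, a higher number a weaker inhibitor), and lies within the scatter of compound 3 (`COc1ccc(-c2c(C(=O)c3cc(OC)c(OC)c(OC)c3)sc3ccccc23)cc1`), which gives 1600 nM there. Compound 1 (`COc1cc(C(=O)c2sc3ccccc3c2-c2ccc(F)cc2)cc(OC)c1OC`) gives 3200 nM and lies only modestly apart from compound 2 (a 2.3-fold lower number from compound 1 to compound 2 (0.36 log units; beyond the scatter)), while compound 3 does not clearly differ from it (a 2.0-fold lower number from compound 1 to compound 3 (0.30 log units; within the scatter)). Compound 4 (`COc1cc(C(=O)c2sc3ccccc3c2-c2ccc(SC)cc2)cc(OC)c1OC`) has methylsulfanyl in place of methyl on an aromatic carbon. The one measured replacement of that methyl, in compound 3 (a 1.1-fold higher number from compound 2 to compound 3 (0.06 log units; within the scatter)), was small, and every measured swap at this carbon stayed modest, so no step beyond the scatter is expected in this assay for the new group. The expected step is a 1.1-fold higher number from compound 2 to compound 4 (0.03 log units; within the scatter) by this estimate. Compound 4 is estimated at 1500 nM with a range of 600 nM to 3800 nM for now.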

Compound 4, half-maximal inhibitory concentration: 1300 nM
Compound 4: the middle estimate sits 1.2-fold (0.06 log units) above what was measured; low and high end bracket the measured number.
By their numbers in this assay, from the lowest: compounds 4, 2, 3 and 1 (each within the scatter of the next, the first and the last beyond it).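

In this assay, the carbon para to a large group accepts methylsulfanyl with no shift readable against methyl (a 1.1-fold lower number from compound 2 to compound 4 (0.03 log units; within the scatter)) or methoxy (a 1.2-fold lower number from compound 3 to compound 4 (0.09 log units; within the scatter)), so a group carrying sulfur fits the same level as compound 2 and compound 3. Fluoro is the only group set apart from methylsulfanyl (a 2.5-fold lower number from compound 1 to compound 4 (0.39 log units; beyond the scatter)), though compound 3 remains within the scatter of compound 1. Nothing measured here accounts for these groups reading alike.

Going by these compounds, whether an amine, a carboxylic acid or a longer chain such as ethylsulfanyl at this carbon would stay at this level remains open.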